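Trimming the Carboxylic Acid Chain of Compound 3

The source may hold more compounds than are shown below. What is called first, only, known or untested is meant among the compounds shown, and "the series" means these compounds.

In a functional assay on HCT-116 cells (Homo sapiens) for antiproliferative activity, read by MTT assay, with a stated time of 72 h (on this read-out lower numbers stand for stronger inhibition and higher numbers for weaker inhibition), compound 1 `O=C(NO)c1ccc(NCCOc2ccc3cc2COC/C=C/COCc2cccc(c2)-c2ccnc(n2)N3)cc1` gives 3200 nM and compound 2 `O=C(NO)c1cccc(NCCOc2ccc3cc2COC/C=C/COCc2cccc(c2)-c2ccnc(n2)N3)c1` gives 2010 nM. The step between them is a 1.6-fold lower number from compound 1 to compound 2 (0.20 log units; within the scatter). Compound 3 `O=C(O)CCCCCCCOc1ccc2cc1COC/C=C/COCc1cccc(c1)-c1ccnc(n1)N2` gives 8040 nM, the highest of the three numbers. Compound 4 `O=C(O)CCCCCCOc1ccc2cc1COC/C=C/COCc1cccc(c1)-c1ccnc(n1)N2` differs from compound 3 by a single change at the end of the chain: carboxy in place of carboxymethyl on a saturated chain carbon, six bonds along the chain from an oxygen on an aromatic ring. This places carboxy in place of carboxymethyl on a saturated chain carbon, six bonds along the chain from an oxygen on an aromatic ring.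

Going by the values given here, no measured pair isolates this change. The nearest evidence comes from the two steps that replace the whole hydroxycarbamoyl-bearing arm with the acid chain: a 2.5-fold higher number from compound 1 to compound 3 (0.40 log units; beyond the scatter) and a 4.0-fold higher number from compound 2 to compound 3 (0.60 log units; beyond the scatter). Both are modest, so the much smaller change to compound 3 is expected to produce no step beyond the scatter in this assay. The estimate implies a 1.0-fold lower number from compound 3 to compound 4 (0.00 log units; within the scatter), which is an expected absence of real change. For compound 4 the estimated value is 8000 nM, with an expected range of 4000 nM to 16000 nM.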

Compound 4, half-maximal inhibitory concentration: 6060 nM
Beside the measured number, compound 4's estimate is 1.3-fold (0.12 log units) above it; measured number inside the range.
By their numbers in this assay, from the lowest: compounds 2, 1, 4 and 3 (each within the scatter of the next, the first and the last beyond it).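

Carboxy in place of carboxymethyl, at this place six bonds along the chain from an oxygen on an aromatic ring, gives a 1.3-fold lower number from compound 3 to compound 4 (0.12 log units; within the scatter) in this assay, so this single change to the acid chain does not separate the two compounds. Set against the arms bearing hydroxycarbamoyl, the picture shifts only in part: a 1.9-fold higher number from compound 1 to compound 4 (0.28 log units; within the scatter), whereas a 3.0-fold higher number from compound 2 to compound 4 (0.48 log units; beyond the scatter), and compound 3 had stood beyond the scatter from both. Nothing available here explains these steps.

The compounds shown leave open how a much shorter acid chain, such as 2-carboxyethyl, or a longer chain would read in this assay. They also leave open whether an amine or a primary amide at the end of the chain would read any differently from the carboxylic acid.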